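A few compounds are considered here, and "the series" means these few. Any claim that something is new, unique, unknown or untested is made for them only; others in the source may bear on it.

Compound 1 `O=C(O)[C@@H]1CCCN1C(=O)CN(c1nc(Cl)nc2[nH]cnc12)C1CC1` — 23.6%
Compound 2 `O=C(CN(c1nc(Cl)nc2[nH]cnc12)C1CC1)N[C@@H](CC(=O)OCc1ccccc1)C(=O)OCc1ccccc1` — 12.1%
Compound 3 `O=C(OCc1ccccc1)[C@@H]1CCCN1C(=O)CN(c1nc(Cl)nc2[nH]cnc12)C1CC1` — 38.4%

In a functional assay on the whole organism (Tail, strain ICR) with Mus musculus as the target, in the tail flick test, with a stated time of 120 min, at a dose of 25 umol/kg by the oral route (on this read-out lower numbers stand for a weaker effect and higher numbers for a stronger effect at the one dose given), compound 1 gives 23.6%, the second highest of the three numbers. Compound 2 gives 12.1%, a lower number, and its gap to compound 1 is larger than the usual scatter; compound 3 gives 38.4%, a higher number, and its gap to compound 1 is also larger than the usual scatter. Going by the values given here, the only step between compounds that differ in one place is a number 14.8 percentage points higher from compound 1 to compound 3 (beyond the scatter), brought about by benzyl in place of hydrogen on an oxygen next to a carbonyl group.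

Compound 4 `C[C@H](NC(=O)CN(c1nc(Cl)nc2[nH]cnc12)C1CC1)C(=O)O` differs from compound 1 in another way: (1-carboxyethyl)amino in place of 2-carboxypyrrolidin-1-yl on a carbonyl carbon. Among the compounds with values here, no measured pair isolates this change. The step from compound 1 to compound 3 concerns only the oxygen of the carboxylic acid and leaves the ring untouched, and compound 2 differs from compound 1 in both the amino acid part and its esters, so its lower value cannot be split into parts. With nothing that bears directly on the change, the expectation for compound 4 in this assay is a number within the scatter of compound 1. Compound 4 is therefore estimated at 21%, within a range of 8% to 35%. The expected step is a number 2.6 percentage points lower from compound 1 to compound 4 (within the scatter).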

Compound 4, a percentage reported as activity, at one dose (the size of the read-out at that dose, not a potency): 28.4%
Estimate against measurement, compound 4: 7.4 percentage points below, and the stated range covers the measured number.
By their numbers in this assay, from the lowest: compound 2; then compounds 1, 4 and 3 (each within the scatter of the next, the first and the last beyond it).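

In this assay, replacing 2-carboxypyrrolidin-1-yl on a carbonyl carbon with (1-carboxyethyl)amino gives a number 4.8 percentage points higher from compound 1 to compound 4 (within the scatter) and so opens the five-membered ring position to change without a shift that can be told from the scatter: in this pair, the read-out at the one dose does not depend on that ring being present. Going by these compounds alone, the earlier step, a number 14.8 percentage points higher from compound 1 to compound 3 (beyond the scatter) with benzyl in place of hydrogen on the acid oxygen, left the ring untouched, so this is the first readable view of the amino acid part itself, with the free carboxylic acid kept in both compounds. Nothing measured on these compounds explains why the two groups read alike.

On these data alone, what stays open is whether a benzyl ester on the (1-carboxyethyl)amino group would produce a step like the one seen on the ring-bearing acid, and whether the lower reading of compound 2 belongs to its longer chain or to its two esters. Also open, as far as these compounds go, is how a six-membered piperidine ring, an isopropyl side chain or a primary amide in place of the carboxylic acid would read at this place.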